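Aminopiperidine replacement in a fused-ring chemokine receptor series

The source may hold more compounds than are shown below. What is called first, only, known or untested is meant among the compounds shown, and "the series" means these compounds.

Compound 1 `CN(C[C@H]1Cc2c(cccc2N2CCC(N)CC2)CN1)[C@H]1CCCc2cccnc21` gives 33.4 nM in a functional assay on CCRF-CEM cells for antagonist activity at C-X-C chemokine receptor type 4 (Homo sapiens), read by calcium flux, with stated times of 25 min and 90 s; on this read-out lower numbers stand for stronger inhibition and higher numbers for weaker inhibition. Among the three compounds measured it gives the highest number; the nearest is compound 3 and the furthest compound 2. Compound 2 `CN(C)[C@@H]1CCN(c2cccc3c2C[C@H](CN(C)[C@H]2CCCc4cccnc42)NC3)C1` gives 10.4 nM, and compound 3 `CN1CC[C@H]2CN(c3cccc4c3C[C@H](CN(C)[C@H]3CCCc5cccnc53)NC4)C[C@H]21` gives 11.4 nM. Both steps from compound 1 change the same group on the aromatic carbon: a 3.2-fold lower number from compound 1 to compound 2 (0.51 log units; beyond the scatter) and a 2.9-fold lower number from compound 1 to compound 3 (0.47 log units; beyond the scatter). Between compound 2 and compound 3 the step is a 1.1-fold higher number from compound 2 to compound 3 (0.04 log units; within the scatter).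

Compound 4 `CN(C[C@H]1Cc2c(cccc2N[C@H]2CC[C@H](N)CC2)CN1)[C@H]1CCCc2cccnc21` carries a further change at that position: (4-aminocyclohexyl)amino in place of 4-aminopiperidin-1-yl on an aromatic carbon. The two measured steps that bear on it, from compound 1 to compound 2 and from compound 1 to compound 3, each moved the number modestly lower after a replacement of the 4-aminopiperidin-1-yl group. Neither of them, however, replaced the ring nitrogen by a ring of carbon only with an amino linkage, so the direction for compound 4 is not settled by what has been measured. A modest step is expected in this assay for compound 4, roughly a 1.3-fold lower number from compound 1 to compound 4 (0.13 log units; within the scatter), with a wide range allowed. The estimate for compound 4 is 25 nM, between 8 nM and 80 nM.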

Compound 4, half-maximal inhibitory concentration: 755 nM
Beside the measured number, compound 4's estimate is 30-fold (1.48 log units) below it, outside the stated range (above it).
By their numbers in this assay, from the lowest: compounds 2 and 3 (each within the scatter of the next); then compound 1; then compound 4.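

In this assay, this position on an aromatic carbon does not accept every amino-bearing ring: (4-aminocyclohexyl)amino in place of 4-aminopiperidin-1-yl gives a 23-fold higher number from compound 1 to compound 4 (1.35 log units; beyond the scatter), the opposite direction to the earlier replacements of that group. The loss is larger still against the two replacements that had lowered the number, with a 66-fold higher number from compound 3 to compound 4 (1.82 log units; beyond the scatter) and a 73-fold higher number from compound 2 to compound 4 (1.86 log units; beyond the scatter), so the choice of group at this one place spans a large range on the shared core. No measurement shown offers an explanation for this loss.

The change alters two things at once, swapping a ring nitrogen bonded to the aromatic carbon for an amino linkage and the piperidine ring for a ring of carbon only, and the compounds shown do not separate these two parts of the step. Still open, going by these compounds, is where a 4-aminocyclohexyl group bonded directly to the aromatic carbon, without the amino linkage, or a piperazin-1-yl group would fall.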